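The compounds below may be only part of what the source reports. "The series", "measured", "known", "first", "only" and "open" are said of these compounds alone.

Compound 1 `CC1CCN(c2c(S(=O)(=O)c3ccc(Cl)c(Cl)c3)cnc3ccc(F)cc23)CC1`: 91%
Compound 2 `Cc1ccc2ncc(S(=O)(=O)c3ccc(F)c(Cl)c3)c(N3CCC(C)CC3)c2c1`: 93%
Compound 3 `Cc1cc(C)cc(S(=O)(=O)c2cnc3ccc(F)cc3c2N2CCC(C)CC2)c1`: 83%

In an assay on isolated protein for displacement of a labelled ligand from metabotropic glutamate receptor 5 (Homo sapiens), with a stated time of 60 min, tested at 1 uM (on this read-out lower numbers stand for less inhibition and higher numbers for more inhibition at the one concentration tested (going by the name of the read-out)), compound 3 gives 83%, the smallest of the three numbers, though its gaps to compound 1 and to compound 2 both fall within the scatter, so no order among the three is established. Compound 4 `CC1CCN(c2c(S(=O)(=O)c3ccc(F)c(Cl)c3)cnc3ccc(F)cc23)CC1` is the next member: 3-chloro-4-fluorophenyl in place of 3,5-dimethylphenyl on a sulfonyl sulfur. Going by the values given here, the one measured step that bears on this is the reverse exchange of the dihalophenyl for the dimethylphenyl, a number 8 percentage points lower from compound 1 to compound 3 (within the scatter). Compound 2 carries the same 3-chloro-4-fluorophenyl on a different core and gives 93%. Compound 4 is therefore expected to move back up by a step of about a number 7 percentage points higher from compound 3 to compound 4 (within the scatter), which stays within the scatter. Compound 4 is estimated at 90%, range 80% to 97%.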

Compound 4, a percentage reported as inhibition, at one concentration (the size of the read-out at that concentration, not a potency): 95%
For compound 4 the middle estimate is 5 percentage points below the measured one; the range from low to high includes it.
By their numbers in this assay, from the lowest: compounds 3, 1, 2 and 4 (each within the scatter of the next, the first and the last beyond it).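

In this assay, going by these compounds alone, the exchange on a sulfonyl sulfur of 3,5-dimethylphenyl for 3-chloro-4-fluorophenyl gives a number 12 percentage points higher from compound 3 to compound 4 (beyond the scatter) and so is the first single change to clear the scatter. Fluoro in place of methyl on an aromatic carbon gives a number 2 percentage points higher from compound 2 to compound 4 (within the scatter) and fluoro in place of chloro on an aromatic carbon gives a number 4 percentage points higher from compound 1 to compound 4 (within the scatter) and so neither exchange separates its pair. Nothing available accounts for the step from the dimethylphenyl to the halogenated ring.

Compounds 1, 2 and 4 stay unresolved at this single concentration. Open too, on these data alone, is how an aryl carrying an amine or a carboxylic acid behaves on the sulfonyl sulfur.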